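The source may report more compounds than this note shows. Statements on the series, on what has been measured and on what is new or still open speak of the compounds shown alone.

Measured so far:
compound 1, `COc1ccc(/C=N/N(C)C(=O)c2ccccc2OC)cc1OC`, 53%
compound 2, `COc1ccc(/C=N/N(C)c2ncnc3ccccc23)cc1OC`, 49%

Both values come from a functional assay on the whole organism (lung, strain A/J) for inhibition, with Mus musculus as the target, with stated times of 1 h and 18 h, at a dose of 100 umol/kg by the oral route; on this read-out lower numbers stand for less inhibition and higher numbers for more inhibition at the one dose given (going by the name of the read-out). Compound 1 holds the highest of the two numbers; the nearest is compound 2, whose number lies lower by an amount within the usual scatter, so no order between compound 1 and compound 2 can be read from these two values.

The next compound to be measured is compound 3, `COc1ccc(/C=N/N(C)C(=O)c2ccccc2)cc1OC`. It differs from compound 1 in one place: hydrogen in place of methoxy on an aromatic carbon. The change sits on an aromatic carbon of a six-membered aromatic ring of carbon only, ortho to a large group.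

Going by the values given here, no measured pair shows this change, so there is no step to lean on. The two measured compounds carry different groups on the shared core yet land within the scatter of each other, which gives no hint that the read-out in this assay moves much here. The expected step is a number 6 percentage points lower from compound 1 to compound 3 (within the scatter), a small drop that need not exceed the scatter. Compound 3 is estimated at 47%, with a range from 30% to 64%.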

Compound 3, a percentage reported as inhibition, in the whole organism at one dose (the size of the read-out at that dose, not a potency): 68%
Compound 3: the middle estimate sits 21 percentage points below what was measured, and the stated range ends below it.
By their numbers in this assay, from the lowest: compounds 2 and 1 (each within the scatter of the next); then compound 3.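

In this assay, going by these compounds alone, hydrogen in place of methoxy gives a number 15 percentage points higher from compound 1 to compound 3 (beyond the scatter) and is the first single change whose step lies beyond the scatter. On an aromatic carbon ortho to a large group, then, the read-out at this one dose responds to the substituent, and for this pair the 2-methoxyphenyl to phenyl change costs no inhibition. Nothing measured here bears on the reason for this step.

Going by these compounds, one pair gives only two points at this position, so it remains open whether the read-out tracks the size of the group or something else about it. An amine, a hydroxy group or a longer chain such as ethoxy on the same aromatic carbon would show whether hydrogen or methoxy marks the better end of the range.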